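Distal aryl exchange on the shared core: pyridin-4-yl analogue

A few compounds are considered here, and "the series" means these few. Any claim that something is new, unique, unknown or untested is made for them only; others in the source may bear on it.

Numbers so far in a functional assay on KB cells (Homo sapiens) for inhibition, with a stated time of 72 h; on this read-out lower numbers stand for stronger inhibition and higher numbers for weaker inhibition:
compound 1 `COc1ccc(S(=O)(=O)N2CCc3cccc(-c4ccc([N+](=O)[O-])cc4)c32)cc1`: 52.5 nM
compound 2 `COc1ccc(S(=O)(=O)N2CCc3cccc(-c4cccnc4)c32)cc1`: 95.9 nM
compound 3 `COc1ccc(S(=O)(=O)N2CCc3cccc(-c4ccc(F)c(F)c4)c32)cc1`: 45 nM

Compound 1 holds the second highest of the three numbers. Its nearest neighbour is compound 3, with a step of a 1.2-fold lower number from compound 1 to compound 3 (0.07 log units; within the scatter); the furthest is compound 2, with a step of a 1.8-fold higher number from compound 1 to compound 2 (0.26 log units; within the scatter). Between the other two members the step is a 2.1-fold lower number from compound 2 to compound 3 (0.33 log units; beyond the scatter), the only one of the three that reaches beyond the scatter.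

Compound 4 `COc1ccc(S(=O)(=O)N2CCc3cccc(-c4ccncc4)c32)cc1` differs from compound 1 in one place: pyridin-4-yl in place of 4-nitrophenyl on an aromatic carbon. The measured step that bears most directly on it is a 1.8-fold higher number from compound 1 to compound 2 (0.26 log units; within the scatter), where a pyridinyl ring likewise took the place of the 4-nitrophenyl of compound 1 and the number stayed within the scatter. The step of a 1.2-fold lower number from compound 1 to compound 3 (0.07 log units; within the scatter) shows that exchanging this distal ring can also leave the number essentially unchanged. The expectation in this assay for compound 4 is therefore a small upward step, a 1.7-fold higher number from compound 1 to compound 4 (0.23 log units; within the scatter), quite possibly nothing beyond the scatter.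

Compound 4 is estimated at 90 nM, with a range of 40 nM to 200 nM.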

Compound 4, half-maximal inhibitory concentration: 96 nM
Estimate against measurement, compound 4: 1.1-fold (0.03 log units) below; the measured number falls inside the stated range.
By their numbers in this assay, from the lowest: compounds 3, 1, 2 and 4 (each within the scatter of the next, the first and the last beyond it).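

In this assay, pyridin-4-yl in place of pyridin-3-yl leaves the number unchanged within the scatter (a 1.0-fold higher number from compound 2 to compound 4 (0.00 log units; within the scatter)), so at this aromatic carbon compound 2 and compound 4 cannot be told apart, and the place of the ring nitrogen has no readable effect in this pair. The pyridin-4-yl ring now also stands apart from the 3,4-difluorophenyl ring, modestly but beyond the scatter (a 2.1-fold higher number from compound 3 to compound 4 (0.33 log units; beyond the scatter)), which gives a second pyridinyl compound at that distance from compound 3, whereas the step from the 4-nitrophenyl stays within the scatter (a 1.8-fold higher number from compound 1 to compound 4 (0.26 log units; within the scatter)), so compound 1 cannot be separated from compound 4. Nothing available on these compounds accounts for the gap between the pyridinyl rings and the 3,4-difluorophenyl ring.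

The compounds shown leave open how far this distal position tolerates groups of another kind, such as a carboxylic acid or a dimethylamino group on the ring, or a saturated ring such as piperidin-4-yl. On these data alone, it also remains open whether the modest separation from compound 3 would widen with a pyridin-2-yl ring or a single fluoro substituent.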